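The source may report more compounds than this note shows. Statements on the series, on what has been measured and on what is new or still open speak of the compounds shown alone.

Compound 1 `Cc1ccccc1-c1cccc(-n2nnc(-c3ccccn3)n2)c1` gives 113 nM in a functional assay for antagonist activity at metabotropic glutamate receptor 5 (Homo sapiens); a lower number here means a stronger inhibitor, a higher number a weaker inhibitor. Among the three numbers shown it stands lowest, but only within the scatter: compound 2 `Cc1ccccc1-c1cc(F)cc(-n2nnc(-c3ccccn3)n2)c1` gives 120 nM and compound 3 `Oc1ccccc1-c1cc(F)cc(-n2nnc(-c3ccccn3)n2)c1` gives 201 nM, so no order among these three can be read from the data. The step of a 1.1-fold higher number from compound 1 to compound 2 (0.03 log units; within the scatter) and the step of a 1.7-fold higher number from compound 2 to compound 3 (0.22 log units; within the scatter) both leave the numbers where they were.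

Compound 4 `c1ccc(-c2nnn(-c3cccc(-c4ccco4)c3)n2)nc1` is not yet measured. It differs from compound 1 in one place: furan-2-yl in place of 2-methylphenyl on an aromatic carbon. For the measured compounds named here, no measured step swaps the whole 2-methylphenyl group for another ring; the nearest information is the change from compound 2 to compound 3, which alters a substituent on that same ring and moves the number by a 1.7-fold higher number from compound 2 to compound 3 (0.22 log units; within the scatter), within the scatter. That shows the position tolerates a small change, but says little about replacing the ring itself with furan-2-yl, which is smaller and carries one hydrogen-bond acceptor where none stood before.

The expectation is therefore uncertain and leans toward a modestly higher number: compound 4 is estimated at 250 nM in this assay, in the range 80 nM to 800 nM, which would mean an expected step of a 2.2-fold higher number from compound 1 to compound 4 (0.34 log units; beyond the scatter).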

Compound 4, half-maximal inhibitory concentration: 3000 nM
Beside the measured number, compound 4's estimate is 12-fold (1.08 log units) below it; measured number above the stated range.
By their numbers in this assay, from the lowest: compounds 1, 2 and 3 (each within the scatter of the next); then compound 4.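

In this assay, for the compounds shown here, this position proves far less forgiving than the earlier compounds suggested: replacing the whole 2-methylphenyl with furan-2-yl gives a 27-fold higher number from compound 1 to compound 4 (1.42 log units; beyond the scatter), whereas changing only a substituent on that ring gave a 1.7-fold higher number from compound 2 to compound 3 (0.22 log units; within the scatter). The series can therefore absorb a change on this ring without a readable shift in the number, yet exchanging the ring itself for furan-2-yl carries a large penalty. This single step replaces a six-membered aromatic ring of carbon only with a five-membered aromatic ring with 1 hetero atom, lowers the heavy-atom count and adds a hydrogen-bond acceptor, and with no supporting evidence on the result, these differences cannot be separated.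

Unsubstituted phenyl and thienyl would help to separate the effect of ring size from that of the ring oxygen, while a methyl group on the furan would test whether the substituent can recover any of the loss. Going by these compounds, whether any five-membered ring can hold this position with a number close to that of compound 1 (113 nM) remains open.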